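Chloro in place of fluoro on compound 1

This account rests on a few compounds, and the source may have more. Where it says the series, first, only, none or still open, it means among the compounds named here.

In an ADME assay on the whole organism for pharmacokinetics, with Rattus norvegicus as the target, at a dose of 10 mg/kg by the oral route (on this read-out lower numbers stand for lower oral bioavailability and higher numbers for higher oral bioavailability), compound 1 `CC#C[C@@H](Cc1nnn[nH]1)c1ccc(OCc2ccc3sc(F)c(-c4ccccc4C)c3c2)cc1` gives 62.3% and compound 2 `CC#C[C@@H](Cc1nnn[nH]1)c1ccc(OCc2ccc3scc(-c4ccc(OCCCS(C)(=O)=O)cc4C)c3c2)cc1` gives 56.8% which places the two within the scatter of each other. Compound 3 `CC#C[C@@H](Cc1nnn[nH]1)c1ccc(OCc2ccc3sc(Cl)c(-c4ccccc4C)c3c2)cc1` differs from compound 1 by chloro in place of fluoro on an aromatic carbon with chloro in place of fluoro on an aromatic carbon next to the ring sulfur. Among the compounds with values here, no measured pair shows a change at this place. The expected size of the step is none beyond the scatter: an estimated a number 4.3 percentage points lower from compound 1 to compound 3 (within the scatter) with no firm direction. In this assay the estimated value for compound 3 is 58% within a range of 42% to 72% for repeat measurements.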

Compound 3, oral bioavailability: 72%
Compound 3: the middle estimate sits 14 percentage points below what was measured, within the range that was stated.
By their numbers in this assay, from the lowest: compounds 2, 1 and 3 (each within the scatter of the next, the first and the last beyond it).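

Chloro in place of fluoro on an aromatic carbon next to the ring sulfur gives a number 9.7 percentage points higher from compound 1 to compound 3 (within the scatter) in this assay and is the first step that can be read at this position. With the 2-methylphenyl group held constant, this position accepts either halogen without a change beyond the scatter. Nothing measured here gives a reason for this step.

As far as these compounds go, it remains open whether a group other than a halogen at this position, such as an amine, a nitrile or a carboxylic acid, would also stay within the scatter of compound 1.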